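Swapping hydroxy for sulfanyl on a methylene nucleoside core

The source may hold more compounds than are shown below. What is called first, only, known or untested is meant among the compounds shown, and "the series" means these compounds.

Two nucleoside analogues sharing a methylene-bearing sugar core have been tested in a functional assay on MT4 cells (Homo sapiens) for inhibition; on this read-out higher numbers stand for weaker inhibition and lower numbers for stronger inhibition. Compound 1 `C=C1[C@@H](O)[C@H](n2ccc(=O)[nH]c2=O)O[C@@H]1CO` carries a pyrimidine base and gives 450000 nM. Compound 2 `C=C1[C@H](n2cnc3c(O)nc(N)nc32)O[C@H](CO)[C@H]1O` carries a fused purine base and gives 150000 nM. Among these two numbers compound 2 stands lowest, and its gap to compound 1 lies beyond the usual scatter, so compound 2 is the stronger inhibitor of the pair.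

Compound 3 `C=C1[C@H](n2cnc3c(S)nc(N)nc32)O[C@H](CO)[C@H]1O` has not yet been measured. It keeps the sugar core and the fused base of compound 2 but differs in a single spot: sulfanyl in place of hydroxy on an aromatic carbon. Within the data shown here, no pair of measured compounds shows what such a one-atom exchange does here, so the size of the step is uncertain. A modest change is expected, with no firm direction, the step from compound 2 to compound 3 estimated at a 1.5-fold lower number from compound 2 to compound 3 (0.18 log units; within the scatter). Compound 3 is therefore expected to give about 100000 nM, with a plausible range from 30000 nM to 400000 nM.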

Compound 3, half-maximal inhibitory concentration: 480 nM
For compound 3 the middle estimate is 210-fold (2.32 log units) above the measured one; measured number below the stated range.
By their numbers in this assay, from the lowest: compound 3; then compound 2; then compound 1.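

Exchanging hydroxy for sulfanyl on this aromatic carbon gives a 310-fold lower number from compound 2 to compound 3 (2.49 log units; beyond the scatter) in this assay and shows that this position answers strongly to a change of a single atom. The two groups have the same counts of heavy atoms, hydrogen-bond donors and acceptors, and neither carries a net charge, so these counts do not tell them apart; the clearest difference in the computed comparison is sulfur in place of oxygen. Nothing available explains why this exchange has so large an effect.

Still open, from the compounds shown here alone, is whether this result is specific to sulfanyl or would also appear with another group on the same carbon, such as methylsulfanyl, an amine or a chlorine atom. It is also unknown whether a similar exchange would matter on the pyrimidine base of compound 1.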